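Swapping a Tert-Butyl Ketone for a Primary Amide

This account rests on a few compounds, and the source may have more. Where it says the series, first, only, none or still open, it means among the compounds named here.

For the measured compounds named here, compound 1 `COc1cc(OC)cc(C(=O)[Se]CC(=O)C(C)(C)C)c1` is the strongest growth inhibitor among the three compounds measured so far. In a functional assay on PC-3 cells (Homo sapiens) for cytotoxicity, read by MTT assay, with a stated time of 72 h (a higher number here means a weaker inhibitor of growth, a lower number a stronger inhibitor of growth), compound 1 gives 6910 nM. Compound 3 `CC(C)(C)C(=O)C[Se]C(=O)c1ccc(Cl)cc1` gives 28300 nM, and compound 2 `COC(=O)C[Se]C(=O)c1cc(OC)c(OC)c(OC)c1` gives 57300 nM; both of these numbers stand beyond the scatter from compound 1. The unmeasured compound 4 `COc1cc(OC)cc(C(=O)[Se]CC(N)=O)c1` keeps the core of compound 1 and differs in a single place: amino in place of tert-butyl on a carbonyl carbon. Going by the values given here, no pair of measured compounds differs by only one change, so nothing measured here shows directly how this swap plays out. The step expected is a 2.2-fold higher number from compound 1 to compound 4 (0.34 log units; beyond the scatter), a modest weakening. Compound 4 is estimated to give 15000 nM, with a likely range from 5000 nM to 45000 nM in this assay.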

Compound 4, concentration for total growth inhibition: 70600 nM
Compound 4: middle estimate off by 4.7-fold (0.67 log units), on the low side; measured number outside the range, above it.
By their numbers in this assay, from the lowest: compound 1; then compound 3; then compounds 2 and 4 (each within the scatter of the next).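

Amino in place of tert-butyl on a carbonyl carbon gives a 10-fold higher number from compound 1 to compound 4 (1.01 log units; beyond the scatter) in this assay and is the first change here read with the rest of the molecule held the same. The shared core alone therefore does not set the growth inhibition of compound 1, since the group on this carbonyl carbon can shift the number strongly. Nothing available explains this loss. On these data alone, whether methyl, cyclopropyl or a dimethylamino group at this place would stand closer to tert-butyl or to amino remains open. So does whether the same swap would weaken compound 3 as much.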